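This account rests on a few compounds, and the source may have more. Where it says the series, first, only, none or still open, it means among the compounds named here.

Values in a functional assay on CCRF-CEM cells (Homo sapiens) for antiproliferative activity; a higher number here means a weaker inhibitor, a lower number a stronger inhibitor:
- compound 1 `COc1cc(C(=O)c2sc(-c3ccc(Cl)cc3)cc2N)cc(OC)c1OC`: 70 nM
- compound 2 `COc1cc(C(=O)c2sc(-c3cccc([N+](=O)[O-])c3)cc2N)cc(OC)c1OC`: 5.9 nM
- compound 3 `COc1cc(C(=O)c2sc(-c3ccncc3)cc2N)cc(OC)c1OC`: 110 nM

Compound 3 cannot be told apart from compound 1, as a 1.6-fold higher number from compound 1 to compound 3 (0.20 log units; within the scatter) shows. It lies well away from compound 2, with a 19-fold higher number from compound 2 to compound 3 (1.27 log units; beyond the scatter).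

Compound 4 `COc1cccc(-c2cc(N)c(C(=O)c3cc(OC)c(OC)c(OC)c3)s2)c1` has 3-methoxyphenyl in place of pyridin-4-yl, on an aromatic carbon next to the ring sulfur: 3-methoxyphenyl in place of pyridin-4-yl on an aromatic carbon.

The closest measured group is 3-nitrophenyl, and both steps that involve it are large: a 12-fold lower number from compound 1 to compound 2 (1.07 log units; beyond the scatter) and a 19-fold higher number from compound 2 to compound 3 (1.27 log units; beyond the scatter). Among the measured compounds shown here, no measured compound carries 3-methoxyphenyl, so only part of that size is expected to carry over. The expected step, a moderate one beyond the scatter toward a lower number, is a 5.5-fold lower number from compound 3 to compound 4 (0.74 log units; beyond the scatter). For compound 4 the estimated value is 20 nM, with an expected range of 4 nM to 90 nM.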

Compound 4, half-maximal inhibitory concentration: 16 nM
Compound 4: middle estimate off by 1.3-fold (0.10 log units), on the high side; the measured number falls inside the stated range.
By their numbers in this assay, from the lowest: compound 2; then compound 4; then compounds 1 and 3 (each within the scatter of the next).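

Read in this assay, 3-methoxyphenyl at the aromatic carbon next to the ring sulfur improves on both pyridin-4-yl (a 6.9-fold lower number from compound 3 to compound 4 (0.84 log units; beyond the scatter)) and 4-chlorophenyl (a 4.4-fold lower number from compound 1 to compound 4 (0.64 log units; beyond the scatter)), so the low numbers at this position are not confined to 3-nitrophenyl. Nitro still holds an edge over methoxy on the same phenyl ring (a 2.7-fold higher number from compound 2 to compound 4 (0.43 log units; beyond the scatter)), so the choice of substituent there matters beyond the scatter. Nothing available explains these differences.

Still open, as far as these compounds go, is whether an amine or a carboxylic acid on that phenyl ring would fit alongside methoxy and nitro. An ethoxy group would show whether a longer chain is accepted.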